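The source may hold more compounds than are shown below. What is called first, only, known or untested is meant among the compounds shown, and "the series" means these compounds.

Working notes on the series: in a functional assay on cells (Fibroblast) for antiproliferative activity (on this read-out lower numbers stand for stronger inhibition and higher numbers for weaker inhibition), compound 1 `C=CCSS/C=C/C[S+]([O-])C(C)(C)C` gives 33100 nM, while compound 2 `C=CCSS/C=C/C[S+]([O-])CCCN1C(=O)c2ccccc2C1=O` gives 95900 nM. That is the higher of the two numbers, and the gap lies beyond the scatter. Compound 3 `C=CCSS/C=C\C[S+]([O-])CCCN1C(=O)c2ccccc2C1=O` has not been measured yet and differs by one change: the two compounds have the same atoms and bonds; at least one stereo element is drawn with a configuration in one of them and without one in the other: 1 of 2 stereo elements differ; a double bond is drawn E in compound 2 and Z in compound 3. Within the data shown here, no measured pair tests this change, and no step beyond the scatter is expected in this assay. The estimated step is a 1.3-fold lower number from compound 2 to compound 3 (0.11 log units; within the scatter), a slight move towards stronger inhibition at most. For compound 3 the expected value is 75000 nM, with an estimated range of 35000 nM to 150000 nM.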

Compound 3, half-maximal inhibitory concentration: 34600 nM
Estimate against measurement, compound 3: 2.2-fold (0.34 log units) above; measured number below the stated range.
By their numbers in this assay, from the lowest: compounds 1 and 3 (each within the scatter of the next); then compound 2.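

Changing only the configuration of one double bond gives, in this assay, a 2.8-fold lower number from compound 2 to compound 3 (0.44 log units; beyond the scatter). The earlier compounds shown here could not show this: here the read-out responds to double bond geometry with atoms and bonds unchanged. This reading carries one qualification: the fact that one of compounds 2 and 3 is drawn with a defined configuration and the other without, at the place where they differ

As far as these compounds go, whether the same change gives a similar step with the other substituent of compound 1 stays open. Also open, from the compounds shown here alone, is how an amine or a longer chain would read in the Z series.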